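Removing the Chloro Group: From Compound 2 to Compound 3

The source may hold more compounds than are shown below. What is called first, only, known or untested is meant among the compounds shown, and "the series" means these compounds.

Of the compounds shown here, two that share one core have been measured in a functional assay on CHO cells for agonist activity at adenosine receptor A1 (Homo sapiens), read by ERK phosphorylation, tested at 10 uM; a lower number here means a weaker effect, a higher number a stronger effect of the compound at the concentration tested. Compound 1, `Nc1sc2c(c1C(=O)c1cccc(C(F)(F)F)c1)CCCCCC2`, gives 65% in this assay. Compound 2, `Nc1sc2c(c1C(=O)c1ccc(Cl)cc1)CCCCCC2`, gives 63% in this assay. Compound 2 thus holds the lower of the two numbers, but its value sits within the scatter of compound 1, so the two cannot be told apart on these data.

Compound 3, `Nc1sc2c(c1C(=O)c1ccccc1)CCCCCC2`, has not yet been measured in this assay. It differs from compound 2 in one place: hydrogen in place of chloro on an aromatic carbon. The chloro group of compound 2 sits on an aromatic carbon of a six-membered aromatic ring of carbon only, para to a large group, and in compound 3 a hydrogen stands there instead.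

Among the measured compounds shown here, no measured pair shows what this change does. With compound 1 at 65% and compound 2 at 63%, both carrying a group on that ring, losing it is expected to lower the number in this assay somewhat, though a step inside the scatter is possible. The expected step is a number 8 percentage points lower from compound 2 to compound 3 (within the scatter). Compound 3 is expected to reach about 55%, within 35% to 72%.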

Compound 3, a percentage reported as activity, at one concentration (the size of the read-out at that concentration, not a potency): 36%
Estimate against measurement, compound 3: 19 percentage points above; the measured number falls inside the stated range.
By their numbers in this assay, from the lowest: compound 3; then compounds 2 and 1 (each within the scatter of the next).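

In this assay replacing chloro with hydrogen gives a number 27 percentage points lower from compound 2 to compound 3 (beyond the scatter) and replacing trifluoromethyl with hydrogen gives a number 29 percentage points lower from compound 1 to compound 3 (beyond the scatter) on the same aromatic ring. The earlier pair could not show this: compound 1 and compound 2 both carry a group on that ring and lie within the scatter of each other, so nothing yet revealed what the ring does without one. Compound 3 supplies that reference point and shows that, among these three compounds, the plain phenyl stands apart, while the 4-chlorophenyl of compound 2 and the trifluoromethyl-bearing ring of compound 1 both hold the effect well clear of it; nothing here explains why a hydrogen at this place gives less.

Compound 1 and compound 2 differ in both the group and where it sits, so these data cannot say whether the identity of the group or its place on the ring matters more. As far as these compounds go, it also remains open whether a group of another kind, such as a methoxy group, an amine or a carboxylic acid, para to a large group would keep the effect or lose it as hydrogen does.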